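Oxazoline series: bromo replacing phenoxy on the aryl ring

The source may report more compounds than this note shows. Statements on the series, on what has been measured and on what is new or still open speak of the compounds shown alone.

compound 1 `C=C[C@@H]1OC(CCCCC)=N[C@H]1CO`: > 2000000 nM
compound 2 `C=C[C@@H]1OC(c2ccc(Oc3ccccc3)cc2)=N[C@H]1CO`: 32000 nM

In an assay on isolated protein for inhibition of matrix metalloproteinase-9 (Homo sapiens) (on this read-out higher numbers stand for weaker inhibition and lower numbers for stronger inhibition), compound 1 `C=C[C@@H]1OC(CCCCC)=N[C@H]1CO` reaches only the assay limit, > 2000000 nM. Compound 2 `C=C[C@@H]1OC(c2ccc(Oc3ccccc3)cc2)=N[C@H]1CO` gives 32000 nM in this assay. For the measured compounds named here, compound 2 thus stands as the only number in the set. The other entry is a limit: the limit of > 2000000 nM in this assay, at which 1 of the 2 values shown sits. Going by the values given here, no step between two measured compounds is available, so the size of any change is not yet known.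

Compound 3 `C=C[C@@H]1OC(c2ccc(Br)cc2)=N[C@H]1CO` is not yet measured. It differs from compound 2 by bromo in place of phenoxy on an aromatic carbon. Among the compounds with values here, with no measured step to lean on, the expectation is for weaker inhibition, and the step of a 6.3-fold higher number from compound 2 to compound 3 (0.80 log units; beyond the scatter) is expected to lie beyond the usual scatter. Compound 3 is estimated at 200000 nM, with a range from 30000 nM to 2000000 nM, and with a real chance that this assay returns only a limit for compound 3.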

Compound 3, inhibition constant: 9000 nM
For compound 3 the middle estimate is 22-fold (1.35 log units) above the measured one; measured number below the stated range.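

For the compounds shown here, the first step that can be read falls at this position, on an aromatic carbon para to a group of 9 heavy atoms: bromo in place of phenoxy gives a 3.6-fold lower number from compound 2 to compound 3 (0.55 log units; beyond the scatter) in this assay, which means stronger inhibition. The six-membered aromatic ring of carbon only that phenoxy carries is therefore not required here for inhibition at the level of compound 2, since a single bromine atom with no ring exceeds it. Nothing measured here accounts for the size or direction of this step.

Going by these compounds alone, compound 1 remains a limit, > 2000000 nM, and adds no step. Open, going by these compounds, is how chloro, methoxy or a carboxylic acid at this position would compare with bromo, and whether a longer chain in place of the aryl group would give any readable number.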